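A few compounds are considered here, and "the series" means these few. Any claim that something is new, unique, unknown or untested is made for them only; others in the source may bear on it.

Compound 1 `COc1cc(N2C(N)=C(C#N)C(c3cccc([N+](=O)[O-])c3)C3=C2CC(C)(C)CC3=O)cc(OC)c1OC` is reported in a functional assay on Ehrlich cells (Mus musculus) for cytotoxicity (on this read-out higher numbers stand for weaker inhibition and lower numbers for stronger inhibition), as "not active" (no number reported), with no number given. Compound 2 `COc1cc(N2C(N)=C(C#N)C(c3ccc([N+](=O)[O-])cc3)C3=C2CC(C)(C)CC3=O)cc(OC)c1OC` gives 25000 nM in this assay. Among the measured compounds shown here, compound 3 `COc1cc(N2C(N)=C(C#N)C(c3ccc(O)cc3)C3=C2CC(C)(C)CC3=O)cc(OC)c1OC` gives 75800 nM in this assay, the higher of the two numbers available; the only single-point step, a 3.0-fold higher number from compound 2 to compound 3 (0.48 log units; beyond the scatter), is modest. Compound 4 `COc1cc(N2C(N)=C(C#N)C(c3ccccc3Cl)C3=C2CC(C)(C)CC3=O)cc(OC)c1OC` carries 2-chlorophenyl in place of 4-hydroxyphenyl on a saturated ring carbon. For the measured compounds named here, no measured step covers this exchange: the step from compound 2 to compound 3 swaps nitro for hydroxy on the aromatic carbon, and the unnumbered entry for compound 1 adds nothing that can be used. With one modest step in the whole set, the expectation for compound 4 is a step of a 1.5-fold lower number from compound 3 to compound 4 (0.18 log units; within the scatter), within the scatter. Compound 4 is estimated at 50000 nM, expected between 12000 nM and 200000 nM.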

Compound 4, half-maximal inhibitory concentration: "not active" (no number reported)
Compound 4: no number reported, so the estimate cannot be set against anything.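

Among the compounds shown here, compound 4 carries no number in this assay, so no step from compound 3 to compound 4 can be read, and no evidence bears on this result. The compounds shown leave open how 2-chlorophenyl compares with 4-hydroxyphenyl on the shared core.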